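The source may hold more compounds than are shown below. What is called first, only, known or untested is meant among the compounds shown, and "the series" means these compounds.

Measured compounds:
Compound 1 `Cc1ccc(NN=C2CCC(C)n3c2ncc(C(=O)O)c3=O)cc1C` gives 6.5 umol/kg in a functional assay on the whole organism with Rattus norvegicus as the target; on this read-out higher numbers stand for an effect only at larger amounts of compound and lower numbers for an effect already at smaller amounts.
Compound 2 `CC1CCC(=NNc2ccc(Cl)c(Cl)c2)c2ncc(C(=O)O)c(=O)n21` gives 0.89 umol/kg.
Compound 3 `CC1CCC(=NNc2cc(Cl)cc(Cl)c2)c2ncc(C(=O)O)c(=O)n21` gives 13.3 umol/kg.

All three share one core and differ only in the group carried on an amine nitrogen. Compound 3 stands at the highest number of the three: the step of a 2.0-fold higher number from compound 1 to compound 3 (0.31 log units; beyond the scatter) is modest, while a 15-fold higher number from compound 2 to compound 3 (1.17 log units; beyond the scatter) is large, so compound 3 is the weakest of the measured set on this read-out.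

Compound 4 `CNN=C1CCC(C)n2c1ncc(C(=O)O)c2=O` is the next compound, and it differs from compound 3 as follows: methyl in place of 3,5-dichlorophenyl on an amine nitrogen. The measured steps, a 7.3-fold lower number from compound 1 to compound 2 (0.86 log units; beyond the scatter), a 2.0-fold higher number from compound 1 to compound 3 (0.31 log units; beyond the scatter) and a 15-fold higher number from compound 2 to compound 3 (1.17 log units; beyond the scatter), all exchange one substituted phenyl for another substituted phenyl at the same position; none of them removes the aromatic ring altogether. They therefore bear on this step only indirectly, showing that the identity of the group on that nitrogen moves the number over a wide span in both directions. Going by the values given here, with no direct precedent, the expected outcome for compound 4 is a further rise in the number, that is, a weaker effect, given as a 4.5-fold higher number from compound 3 to compound 4 (0.65 log units; beyond the scatter), with a wide range. Compound 4 is estimated at 60 umol/kg, between 10 umol/kg and 400 umol/kg.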

Compound 4, dose for 50% inhibition: 17.5 umol/kg
Compound 4: middle estimate off by 3.4-fold (0.54 log units), on the high side, and the stated range covers the measured number.
By their numbers in this assay, from the lowest: compound 2; then compound 1; then compounds 3 and 4 (each within the scatter of the next).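

Swapping the whole aromatic ring for methyl on this amine nitrogen, a change the earlier compounds did not cover, gives a 1.3-fold higher number from compound 3 to compound 4 (0.12 log units; within the scatter) in this assay, so the 3,5-dichlorophenyl group cannot be told apart from a single methyl here. The same replacement gives a 20-fold higher number from compound 2 to compound 4 (1.29 log units; beyond the scatter) and a 2.7-fold higher number from compound 1 to compound 4 (0.43 log units; beyond the scatter), which shows that a phenyl ring at this position goes with a lower number only in the 3,4-dichlorophenyl and 3,4-dimethylphenyl forms, while the 3,5-dichlorophenyl form goes against any rule that a ring alone lowers the number. No measured finding is available to explain this difference between the substituted rings.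

The compounds shown leave open how a phenyl with no substituent, or one carrying a single chlorine, would compare with methyl on this nitrogen, and whether an ethyl group, a longer chain or a benzyl group would stay level with methyl. They also leave open whether the order among these groups would hold if an amide or an ester replaced the carboxylic acid on the shared core.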